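The source may report more compounds than this note shows. Statements on the series, on what has been measured and on what is new or still open speak of the compounds shown alone.

Three compounds have been measured in a functional assay on MCF7 cells (Homo sapiens) for inhibition, read by MTT assay, with a stated time of 24 h; on this read-out lower numbers stand for stronger inhibition of growth and higher numbers for weaker inhibition of growth:

Compound 1, `COc1ccc(C(=O)n2c(-c3cn(C)c4ccccc34)nc3ccccc32)cc1OC`, gives 10200 nM.
Compound 2, `Cn1cc(-c2nc3ccccc3n2C(=O)c2ccccc2Br)c2ccccc21`, gives 70100 nM.
Compound 3, `COc1ccc2c(c1)c(-c1nc3ccccc3n1C(=O)c1ccc(OC)c(OC)c1)cn2C`, gives 6300 nM.

Compounds 1 and 3 share a core that differs in one place, (methoxy in place of hydrogen on an aromatic carbon), and their values are close: a 1.6-fold lower number from compound 1 to compound 3 (0.21 log units; within the scatter). Compound 2 is compound 1 with a different group on the carbonyl carbon, (2-bromophenyl in place of 3,4-dimethoxyphenyl on a carbonyl carbon), and this change weakened growth inhibition: a 6.9-fold higher number from compound 1 to compound 2 (0.84 log units; beyond the scatter).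

Compound 4, `COc1ccc2c(c1)c(-c1nc3ccccc3n1C(=O)c1ccccc1Br)cn2C`, has not yet been measured. It stands to compound 3 as compound 2 stands to compound 1, the change being (2-bromophenyl in place of 3,4-dimethoxyphenyl on a carbonyl carbon), at a place described in the same words in both pairs, so it is the same change made on the core of compound 3. Among the measured compounds shown here, because the only measured instance of this change is a 6.9-fold higher number from compound 1 to compound 2 (0.84 log units; beyond the scatter), and because compound 3 starts from 6300 nM, a step of similar size is expected here: a 6.7-fold higher number from compound 3 to compound 4 (0.82 log units; beyond the scatter). Compound 4 is therefore estimated at 42000 nM in this assay, with a range from 15000 nM to 120000 nM.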

Compound 4, concentration for 50% growth inhibition: 55800 nM
The estimate for compound 4 lay 1.3-fold (0.12 log units) below the measured number, and the stated range covers the measured number.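

In this assay, placing 2-bromophenyl in place of 3,4-dimethoxyphenyl on the carbonyl carbon gives an 8.9-fold higher number from compound 3 to compound 4 (0.95 log units; beyond the scatter), and the change carries from the core of compound 1 to the core of compound 3 with much the same size: the same change on two cores in this assay, a 6.9-fold higher number (0.84 log units; beyond the scatter) from compound 1 to compound 2 and an 8.9-fold higher number (0.95 log units; beyond the scatter) from compound 3 to compound 4, 1.3-fold (0.11 log units) apart, within the scatter of two such steps. Methoxy in place of hydrogen on an aromatic carbon gives a 1.3-fold lower number from compound 2 to compound 4 (0.10 log units; within the scatter), which matches its earlier small step with the other group on the carbonyl carbon: the same change on two cores in this assay, a 1.6-fold lower number (0.21 log units; within the scatter) from compound 1 to compound 3 and a 1.3-fold lower number (0.10 log units; within the scatter) from compound 2 to compound 4, 1.3-fold (0.11 log units) apart, within the scatter of two such steps. Together these show that the two changes behaved consistently across these four compounds, but they do not explain the loss of growth inhibition, and two cores cannot show that the step would hold on a more different core.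

The compounds shown leave open how a group such as a piperazine, a carboxylic acid or a longer alkyl chain would fare on the carbonyl carbon. They also leave open whether a substituent other than methoxy, such as chlorine or hydroxyl, on that aromatic carbon would produce a step beyond the scatter.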